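A few compounds are considered here, and "the series" means these few. Any claim that something is new, unique, unknown or untested is made for them only; others in the source may bear on it.

Going by the values given here, compound 1 `Cn1ncnc1-c1cc(Oc2ccc(NC(=O)Nc3cccc(C(F)(F)F)c3)cc2F)ccn1` is the only member of this small set with a number in an ADME assay on WI-38 cells (Homo sapiens) for cytotoxicity, read by MTT assay, with a stated time of 72 h; a lower number here means a stronger inhibitor, a higher number a weaker inhibitor; there compound 1 gives 22400 nM. Compound 2 `CN(C)CCn1cnnc1-c1cc(Oc2ccc(NC(=O)Nc3ccccc3C(F)(F)F)cc2F)ccn1` reaches only a limit, > 50000 nM. Compound 3 `CN(C)CCn1cnnc1-c1cc(Oc2ccc(NC(=O)Nc3ccc(F)c(F)c3)cc2F)ccn1` likewise reaches only a limit, > 50000 nM. Among the compounds with values here, the one step between measured neighbours, a step that the two limits leave unreadable from compound 2 to compound 3, is therefore not readable, and the limit of > 50000 nM in this assay, at which 2 of the 3 values shown sit, is the only evidence the measured values offer. Compound 4 `CCN(CC)CCn1cnnc1-c1cc(Oc2ccc(NC(=O)Nc3cccc(C(F)(F)F)c3)cc2F)ccn1` differs from compound 1 in one place: 4-(2-(diethylamino)ethyl)-4H-1,2,4-triazol-3-yl in place of 1-methyl-1H-1,2,4-triazol-5-yl on an aromatic carbon. Within the data shown here, no measured step covers this change directly; the two compounds bearing a dialkylaminoethyl chain both sit at the limit. Compound 4 is thus expected to give 40000 nM, within 15000 nM to 100000 nM, a step of a 1.8-fold higher number from compound 1 to compound 4 (0.25 log units; within the scatter) that is estimated to run toward weaker inhibition.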

Compound 4, half-maximal inhibitory concentration: 6920 nM
Beside the measured number, compound 4's estimate is 5.8-fold (0.76 log units) above it; the whole stated range lies above it.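

In this assay, putting 4-(2-(diethylamino)ethyl)-4H-1,2,4-triazol-3-yl in place of 1-methyl-1H-1,2,4-triazol-5-yl next to the ring nitrogen gives a 3.2-fold lower number from compound 1 to compound 4 (0.51 log units; beyond the scatter). Going by these compounds alone, this is the first readable step in the set, and it shows that a change at this position can move the read-out toward stronger inhibition, though only modestly. Compound 4 gives a number and does not join the compounds held at the limit: the limit of > 50000 nM in this assay, at which 2 of the 4 values shown sit.

The compounds shown do not separate the effect of the chain from that of the changed triazole attachment. They also leave open how a morpholine or a carboxylic acid at the end of that chain would read in this assay.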